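This account rests on a few compounds, and the source may have more. Where it says the series, first, only, none or still open, it means among the compounds named here.

Compound 1 `CCCc1nn(C)c2c(NC3CC3)nc(/C=C/c3cccnc3)nc12`: 261000 nM
Compound 2 `COc1cc(/C=C/c2nc(N3CCN(C)CC3)c3sccc3n2)cc(OC)c1OC`: > 1000000 nM

In a functional assay on L02 cells (Homo sapiens) for inhibition, read by Griess assay, with stated times of 1 h and 24 h (on this read-out higher numbers stand for weaker inhibition and lower numbers for stronger inhibition), compound 2 gives only a limit, > 1000000 nM, not a number. Compound 2 therefore stands at the limit of > 1000000 nM in this assay, at which 1 of the 2 values shown sits. In this assay compound 1 gives 261000 nM. Compound 3 `COc1cc(/C=C/c2nc(NCc3ccncc3)c3sccc3n2)cc(OC)c1OC` shares the core of compound 2 and differs by one change: ((pyridin-4-yl)methyl)amino in place of 4-methylpiperazin-1-yl on an aromatic carbon. Among the compounds with values here, no measured pair of compounds shows what such a change does here, so the expected step from compound 2 to compound 3 is uncertain; compound 3 is expected to show an at least 1.6-fold lower number from compound 2 to compound 3 (0.22 log units; that floor lies within the scatter), a modest gain that may not clear the scatter. Compound 3 is estimated at 600000 nM, within 150000 nM to 2000000 nM.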

Compound 3, half-maximal inhibitory concentration: 374000 nM
Estimate against measurement, compound 3: 1.6-fold (0.21 log units) above, within the range that was stated.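

In this assay, within the data shown here, ((pyridin-4-yl)methyl)amino in place of 4-methylpiperazin-1-yl on this aromatic carbon gives an at least 2.6-fold lower number from compound 2 to compound 3 (0.42 log units; beyond the scatter) on the shared core, the first reading of such a change here. On these data alone, the full size of the step stays unknown because the value of compound 2 is a limit and not a number: the limit of > 1000000 nM in this assay, at which 1 of the 3 values shown sits.

The compounds shown leave open whether a benzylamino group, with a plain phenyl ring in place of the pyridine, would give a similar step. They also leave open what a longer chain between the amine and the pyridine would do.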